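A few compounds are considered here, and "the series" means these few. Any claim that something is new, unique, unknown or untested is made for them only; others in the source may bear on it.

In an ADME assay on AD293 cells (Homo sapiens) for cytotoxicity (on this read-out lower numbers stand for higher toxicity in this test and higher numbers for lower toxicity in this test), compound 1 (`C=C1CC[C@@H]2[C@](C)(CO[Si](C)(C)C(C)(C)C)[C@H](O)CC[C@@]2(C)[C@@H]1C/C=C1/C(=O)OC[C@@H]1OC(C)=O`) gives 6830 nM and compound 2 (`C=C1CC[C@H]2[C@@](C)(CCC(=O)[C@@]2(C)CO[Si](C)(C)C(C)(C)C)[C@@H]1C/C=C1/C(=O)OC[C@H]1OC(C)=O`) gives 7350 nM as its value. These two numbers lie within the usual scatter of repeated measurements, so compound 2 stands level with compound 1 on this read-out. The step to compound 3 (`C=C1CC[C@H]2[C@@](C)(CCC(=O)[C@@]2(C)CO[Si](C)(C)C(C)(C)C)[C@@H]1C/C=C1/C(=O)OC[C@@H]1OC(C)=O`) changes configuration alone: the two compounds have the same atoms and bonds and differ only in configuration as drawn: 1 of 6 stereo elements differ; a stereocentre at a saturated ring carbon is drawn S in compound 2 and R in compound 3 is the whole difference, and a stereocentre at a saturated ring carbon is drawn S in compound 2 and R in compound 3. For the measured compounds named here, no measured pair yet shows what a change of this kind does in this assay on its own. Taking compound 2 at 7350 nM as the starting point, no shift beyond the scatter is expected in either direction. The step expected is a 1.1-fold lower number from compound 2 to compound 3 (0.02 log units; within the scatter) and it stays small. Compound 3 is estimated at 7000 nM with a range from 3500 nM to 14000 nM as the expected span.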

Compound 3, half-maximal cytotoxic concentration: 8230 nM
Estimate against measurement, compound 3: 1.2-fold (0.07 log units) below; the range from low to high includes it.
By their numbers in this assay, from the lowest: compounds 1, 2 and 3 (each within the scatter of the next).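

For the compounds shown here, this pair is the first to isolate a change of configuration in this assay: a 1.1-fold higher number from compound 2 to compound 3 (0.05 log units; within the scatter). In this one pair, changing a stereocentre at a saturated ring carbon from S to R does not separate the two compounds on this read-out, something compound 1 and compound 2 could not show. The comparison can be read as the result of that single change for this reason: the fact that compounds 2 and 3 differ only in the configuration as drawn.

On these data alone, it remains open whether this stereocentre would matter as little on a different version of the molecule, as a single pair covers only one structural background. The compounds shown also leave open how the read-out would respond to a new group on the shared core, such as an amine or a carboxylic acid.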